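Amine tail variation on the dichlorophenyl urea analogue

A few compounds are considered here, and "the series" means these few. Any claim that something is new, unique, unknown or untested is made for them only; others in the source may bear on it.

The series shares one core. Compound 1 `CN(C)CCCNc1nc(-c2ccc(NC(=O)Nc3ccc(Cl)cc3)cc2)nc2c(Cl)c(Cl)sc12` gives 230 nM in a functional assay on NCI-H460 cells (Homo sapiens) for cytotoxicity, read by MTT assay, with a stated time of 72 h; on this read-out lower numbers stand for stronger inhibition and higher numbers for weaker inhibition. Compound 2 `CN(C)CCCNc1nc(-c2ccc(NC(=O)Nc3ccc(Cl)cc3Cl)cc2)nc2c(Cl)c(Cl)sc12` gives 980 nM, and compound 3 `Cc1ccc(NC(=O)Nc2ccc(-c3nc(NCCCN(C)C)c4sc(Cl)c(Cl)c4n3)cc2)cc1` gives 1110 nM. Compound 2 stands second highest of the three numbers: a 4.3-fold higher number from compound 1 to compound 2 (0.63 log units; beyond the scatter), whereas a 1.1-fold higher number from compound 2 to compound 3 (0.05 log units; within the scatter). Compound 4 `CCN(CC)CCNc1nc(-c2ccc(NC(=O)Nc3ccc(Cl)cc3Cl)cc2)nc2c(Cl)c(Cl)sc12` differs from compound 2 only in the amine tail: diethylamino in place of (dimethylamino)methyl on a saturated chain carbon, two bonds along the chain from a nitrogen on an aromatic ring. For the measured compounds named here, none of the measured steps touches this chain; a 4.3-fold higher number from compound 1 to compound 2 (0.63 log units; beyond the scatter) and a 4.8-fold higher number from compound 1 to compound 3 (0.68 log units; beyond the scatter) both concern the aryl on the urea. The data give no guide for this change, so for compound 4 no step beyond the scatter is expected in this assay, the estimated change being a 1.0-fold higher number from compound 2 to compound 4 (0.01 log units; within the scatter). Compound 4 is therefore expected near 1000 nM, within 400 nM to 2500 nM.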

Compound 4, half-maximal inhibitory concentration: 1300 nM
Estimate against measurement, compound 4: 1.3-fold (0.11 log units) below, and the stated range covers the measured number.
By their numbers in this assay, from the lowest: compound 1; then compounds 2, 3 and 4 (each within the scatter of the next).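

In this assay, for the compounds shown here, the only step on the amine tail reads a 1.3-fold higher number from compound 2 to compound 4 (0.12 log units; within the scatter), so (3-(dimethylamino)propyl)amino and (2-(diethylamino)ethyl)amino cannot be told apart on the 2,4-dichlorophenyl urea. The steps beyond the scatter therefore remain the two on the urea aryl, a 4.3-fold higher number from compound 1 to compound 2 (0.63 log units; beyond the scatter) and a 4.8-fold higher number from compound 1 to compound 3 (0.68 log units; beyond the scatter). No supporting data bear on the reason for this result.

Going by these compounds, whether the same exchange holds with the urea aryl of compound 1 remains open. So does the outcome for a tail ending in morpholine or piperidine, or for a longer chain.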